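The source may report more compounds than this note shows. Statements on the series, on what has been measured and on what is new or still open speak of the compounds shown alone.

Measured so far:
compound 1 `C/C=C(/C)C(=O)O[C@@H]1C(=O)C(CO)=C[C@@H](OC(=O)/C(C)=C\C)[C@H]1C(C)C`: 800 nM
compound 2 `C/C=C(/C)C(=O)O[C@@H]1C=C(CO)C(=O)[C@@H](OC(=O)[C@]2(C)O[C@@H]2C)[C@@H]1C(C)C`: 1200 nM

In a functional assay on CCRF-CEM cells (Homo sapiens) for cytotoxicity, read by XTT assay, with a stated time of 72 h (on this read-out lower numbers stand for stronger inhibition and higher numbers for weaker inhibition), compound 1 gives 800 nM and stands level with compound 2 within the scatter: a 1.5-fold higher number from compound 1 to compound 2 (0.18 log units; within the scatter). This step places 2,3-dimethyloxiran-2-yl in place of 1-methylprop-1-en-1-yl on a carbonyl carbon, so it bears only indirectly on compound 3 `C/C=C(/C)C(=O)O[C@@H]1C(=O)C(CO)=C[C@@H](OC(=O)/C(C)=C/C)[C@H]1C(C)C`. The change to compound 3 is the two compounds have the same atoms and bonds and differ only in configuration as drawn: 1 of 5 stereo elements differ; a double bond is drawn Z in compound 1 and E in compound 3: a double bond is drawn Z in compound 1 and E in compound 3. For the measured compounds named here, no measured step tests this change, so no shift beyond the scatter is expected. The expected result is a 1.1-fold higher number from compound 1 to compound 3 (0.05 log units; within the scatter). The estimate for compound 3 is 900 nM, within an expected range of 350 nM to 2500 nM.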

Compound 3, half-maximal inhibitory concentration: 1300 nM
Beside the measured number, compound 3's estimate is 1.4-fold (0.16 log units) below it; the range from low to high includes it.
By their numbers in this assay, from the lowest: compounds 1, 2 and 3 (each within the scatter of the next).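

In this assay, the double bond drawn Z then E gives a 1.6-fold higher number from compound 1 to compound 3 (0.21 log units; within the scatter), so this geometry change shows no shift beyond the scatter. The earlier step covered only 2,3-dimethyloxiran-2-yl in place of 1-methylprop-1-en-1-yl on a carbonyl carbon, whereas this pair isolates configuration alone: the fact that compounds 1 and 3 differ only in the configuration as drawn

Still open, from the compounds shown here alone, is whether the other four stereo elements can be changed with equally little shift. Also open, going by these compounds, is whether a longer chain or an amine in place of 1-methylprop-1-en-1-yl would move the number beyond the scatter.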